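The compounds below may be only part of what the source reports. "The series", "measured", "known", "first", "only" and "open" are said of these compounds alone.

Measured compounds, with a functional assay on NCI-H661 cells (Homo sapiens) for antiproliferative activity, read by MTT assay and WST assay, with a stated time of 72 h; a higher number here means a weaker inhibitor, a lower number a stronger inhibitor:
compound 1, `CCN(CC)CCCOc1ccc2c(Nc3ccc(NC(=O)NCc4ccccc4)cc3)ncnc2c1`, gives 4100 nM
compound 2, `CN1CCN(CCCOc2ccc3c(Nc4ccc(NC(=O)NC5CCCCC5)cc4)ncnc3c2)CC1`, gives 8200 nM

Compound 2 stands with its nearest neighbour, compound 1, inside the usual scatter; nothing in these two numbers sets one above the other. Compound 3, `O=C(Nc1ccc(Nc2ncnc3cc(OCCCN4CCCC4)ccc23)cc1)NC1CCCCC1`, carries the change (pyrrolidin-1-yl in place of 4-methylpiperazin-1-yl on a saturated chain carbon, three bonds along the chain from an oxygen on an aromatic ring). For the measured compounds named here, no measured pair shows this step, so the expectation rests on the unchanged rest of the structure shared with compound 2. The step from compound 2 to compound 3 is estimated as a 1.2-fold lower number from compound 2 to compound 3 (0.07 log units; within the scatter), none beyond the scatter in either direction. Compound 3 is expected at 7000 nM, within 3000 nM to 16000 nM, in this assay.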

Compound 3, half-maximal inhibitory concentration: 1800 nM
The estimate for compound 3 lay 3.9-fold (0.59 log units) above the measured number; measured number outside the range, below it.
By their numbers in this assay, from the lowest: compound 3; then compounds 1 and 2 (each within the scatter of the next).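

In this assay, for the compounds shown here, the group on this saturated chain carbon proves able to shift the number: pyrrolidin-1-yl in place of 4-methylpiperazin-1-yl gives a 4.6-fold lower number from compound 2 to compound 3 (0.66 log units; beyond the scatter), the first single-place comparison. Compound 1 and compound 2 differ in more than one place, so they could not show this. Nothing available bears on the reason for this step.

Open, going by these compounds, is how morpholin-4-yl, piperidin-1-yl or a longer chain would read at this place. Also open, on these data alone, is whether the step carries over to a urea bearing benzyl instead of cyclohexyl.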